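Hydroxyl-to-fluorine swap on a dihydroxyphenyl furanone

A few compounds are considered here, and "the series" means these few. Any claim that something is new, unique, unknown or untested is made for them only; others in the source may bear on it.

Compound 2 `O=C1OC(c2ccc(OCc3ccccc3)c(OCc3ccccc3)c2)C(c2ccc(O)cc2)=C1O` was tested in an assay on blood for inhibition of Polyunsaturated fatty acid 5-lipoxygenase (Homo sapiens), tested at 10 uM (on this read-out lower numbers stand for a weaker effect and higher numbers for a stronger effect at the one concentration tested), where compound 2 gives 12.7%. Compound 1 `O=C1OC(c2ccc(OCc3ccccc3)c(OCc3ccccc3)c2)C(c2ccc(F)cc2)=C1O` differs from it by fluoro in place of hydroxy on an aromatic carbon, and in this assay compound 1 gives 0%, a step of a number 12.7 percentage points lower from compound 2 to compound 1 (beyond the scatter). Compound 3 `O=C1OC(c2cc(O)cc(O)c2)C(c2ccc(O)cc2)=C1O` carries a different core; how that core differs from the core of compound 2 is not broken down here. In this assay compound 3 gives 0%, level with compound 1 at the digits reported, and together these two stand lowest of the three numbers.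

Compound 4 `O=C1OC(c2cc(O)cc(O)c2)C(c2ccc(F)cc2)=C1O` has not yet been measured. It differs from compound 3 by fluoro in place of hydroxy on an aromatic carbon, the same change in the same place as that from compound 2 to compound 1. Because that earlier change gave a number 12.7 percentage points lower from compound 2 to compound 1 (beyond the scatter), a further fall would be expected, yet compound 3 already sits at the floor of the read-out, so compound 4 is estimated to show a step of no change at the digits printed from compound 3 to compound 4 (within the scatter). Compound 4 is therefore expected to give 0%, estimated between 0% and 8%.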

Compound 4, a percentage reported as activity, at one concentration (the size of the read-out at that concentration, not a potency): 0%
The estimate for compound 4 equals the measured number at the digits printed, and the stated range covers the measured number.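

In this assay, the swap of 4-hydroxyphenyl to 4-fluorophenyl on the core of compound 3 gives no change at the digits printed from compound 3 to compound 4 (within the scatter), and the two steps on the two cores do not differ beyond what repeated measurements allow: the same change on two cores in this assay, a number 12.7 percentage points lower (beyond the scatter) from compound 2 to compound 1 and no change at the digits printed (within the scatter) from compound 3 to compound 4, 12.7 percentage points apart, within the scatter of two such steps

This agreement is compatible with the change carrying over from one core to the other, but it does not show that it does, since compound 3 already gives 0% and the read-out leaves no room for a further fall on that core. Among these compounds, the only step large enough to read is therefore the one that starts from compound 2 at 12.7%, so the size of the effect on a second core remains unknown.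

The compounds shown leave open how an amine or a carboxylic acid would read in place of the hydroxy group on either core. They also leave open what the same swap would do on a core whose hydroxy compound gives a clearly higher number.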